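Cinnamoyl hydroxamates: aryl ether series, Huh-7 cytotoxicity notes

This account rests on a few compounds, and the source may have more. Where it says the series, first, only, none or still open, it means among the compounds named here.

Measured so far:
- compound 1, `O=C(/C=C/c1ccccc1Oc1ccccc1)NO`: 66000 nM
- compound 2, `O=C(/C=C/c1cccc(OCCOc2ccccc2)c1)NO`: 6000 nM
- compound 3, `O=C(/C=C/c1ccc(OCCc2ccccc2)cc1)NO`: 16000 nM

All three numbers come from an ADME assay on Huh-7 cells (Homo sapiens) for cytotoxicity, read by MTT assay, with a stated time of 3 days; a lower number here means that less compound is tolerated, a higher number that more compound is tolerated. Compound 1 stands highest of the three in this assay: its nearest neighbour is compound 3, which gives 16000 nM, and the one furthest from it is compound 2, which gives 6000 nM. Both gaps lie beyond the usual scatter, so compound 1 is the best tolerated of the measured set.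

Compound 4, `COc1ccccc1/C=C/C(=O)NO`, has not yet been measured in this assay. It is reached from compound 1 by a single change: methyl in place of phenyl on an oxygen on an aromatic ring. Among the compounds with values here, no measured pair shows the effect of such a change, so the expectation rests only on where compound 1 stands.

Compound 4 is expected to move upward from compound 1, by roughly a 1.5-fold higher number from compound 1 to compound 4 (0.18 log units; within the scatter), a step that may or may not clear the scatter. For compound 4 the estimate in this assay is 100000 nM, with a range from 40000 nM to 250000 nM.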

Compound 4, half-maximal cytotoxic concentration: 30000 nM
The estimate for compound 4 lay 3.3-fold (0.52 log units) above the measured number; the measured number lies below the stated range.
By their numbers in this assay, from the lowest: compound 2; then compounds 3 and 4 (each within the scatter of the next); then compound 1.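

Methyl in place of phenyl on an oxygen on an aromatic ring provides the first single-place comparison in the series, and in this assay it gives a 2.2-fold lower number from compound 1 to compound 4 (0.34 log units; beyond the scatter), a modest step beyond the usual scatter. At this position, the phenyl can therefore be exchanged for a much smaller group with no ring, and less compound is tolerated after the exchange. Nothing on hand explains the shift.

Going by these compounds, whether the lower number follows from losing the ring or from losing the heavy atoms stays open, as does the outcome with a cyclohexyl group, a benzyl group or a longer chain on the same oxygen. Compounds 2 and 3 differ from compound 1 in more than one place, so they cannot show whether this step would carry over to other members of the series.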